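Notes on one added methyl: compound 3 to compound 4

A few compounds are considered here, and "the series" means these few. Any claim that something is new, unique, unknown or untested is made for them only; others in the source may bear on it.

Values in a functional assay on SH-SY5Y cells (Homo sapiens) for cytotoxicity, read by MTT assay, with a stated time of 48 h; a higher number here means a weaker inhibitor, a lower number a stronger inhibitor:
- compound 1 `COc1cc(/C=C/C(=O)/C=C/c2nc3c(C)c(C)ccc3n2C)ccc1O` gives 19000 nM
- compound 2 `COc1ccc(/C=C/C(=O)/C=C/c2nc3cc(C)ccc3n2C)cc1O` gives 4800 nM
- compound 3 `COc1ccc(/C=C/C(=O)/C=C/c2nc3c(C)cccc3n2C)cc1O` gives 19100 nM

Compound 3 (19100 nM) stands level with compound 1 (19000 nM) within the scatter, while compound 2 (4800 nM) shows a lower number, beyond the scatter. Compound 4 `COc1ccc(/C=C/C(=O)/C=C/c2nc3c(C)c(C)ccc3n2C)cc1O` has methyl in place of hydrogen on an aromatic carbon, ortho to a methyl group (methyl in place of hydrogen on an aromatic carbon). Among the compounds with values here, no measured pair isolates this change. Compound 1 (19000 nM) shares the methyl groups of compound 4 but differs elsewhere. In this assay the expected change is no step beyond the scatter (a 1.2-fold lower number from compound 3 to compound 4 (0.08 log units; within the scatter)). For compound 4 the estimate is 16000 nM with 8000 nM to 32000 nM as its expected range.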

Compound 4, half-maximal inhibitory concentration: 4800 nM
Compound 4: the middle estimate sits 3.3-fold (0.52 log units) above what was measured; the whole stated range lies above it.
By their numbers in this assay, from the lowest: compounds 2 and 4 (each within the scatter of the next); then compounds 1 and 3 (each within the scatter of the next).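

In this assay, methyl in place of hydrogen on an aromatic carbon, ortho to a methyl group, gives a 4.0-fold lower number from compound 3 to compound 4 (0.60 log units; beyond the scatter) and so this position responds to the change. The second methyl step shows no change at the digits printed from compound 2 to compound 4 (within the scatter) and places compound 4 level with compound 2. With both methyl groups present, 3-hydroxy-4-methoxyphenyl in place of 4-hydroxy-3-methoxyphenyl gives a 4.0-fold lower number from compound 1 to compound 4 (0.60 log units; beyond the scatter) as well, so the methyl change alone does not set the number.

From the compounds shown here alone, whether an amine or a longer chain on this aromatic carbon would move the number remains open. Nothing here gives a reason for these steps.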